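The source may hold more compounds than are shown below. What is called first, only, known or untested is meant among the compounds shown, and "the series" means these compounds.

Measured so far in the series:
Compound 1 `Oc1cccc(CNc2ncnc3c2ncn3C2CCCCO2)c1`. In an ADME assay on BJ cells (Homo sapiens) for cytotoxicity, read by MTT assay, with a stated time of 72 h (a higher number here means a weaker inhibitor, a lower number a stronger inhibitor), compound 1 gives > 100000 nM, which is a limit of the assay and not a number.
Compound 2 `Oc1ccc(CNc2ncnc3c2ncn3C2CCCCO2)cc1`. In this assay compound 2 gives > 100000 nM, again a limit of the assay.
Compound 3 `COc1ccccc1CNc1ncnc2c1ncn2C1CCCCO1`. In this assay compound 3 gives > 100000 nM, also a limit.

Compound 2 therefore stands only at a limit in this assay, with no number of its own, and the two other values shown are limits as well. All three values sit at the same point, as the limit of > 100000 nM in this assay, at which 3 of the 3 values shown sit, records. The steps among the measured compounds are accordingly unreadable: a step that the two limits leave unreadable from compound 1 to compound 2, a step that the two limits leave unreadable from compound 1 to compound 3 and a step that the two limits leave unreadable from compound 2 to compound 3 give no size in either direction.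

The next compound, compound 4 `COc1ccc(CNc2ncnc3c2ncn3C2CCCCO2)cc1`, differs from compound 2 by methyl in place of hydrogen on an oxygen on an aromatic ring, that is, hydroxy to methoxy, 4-hydroxyphenyl to 4-methoxyphenyl on the shared core. Going by the values given here, the steps that bear on it are the ones to and from compound 2, a step that the two limits leave unreadable from compound 1 to compound 2 and a step that the two limits leave unreadable from compound 2 to compound 3, and neither can be read, so no direction and no size beyond the scatter is expected for a step that the limit leaves unreadable from compound 2 to compound 4. Compound 4 is estimated to sit at 150000 nM, within 80000 nM to 500000 nM, most probably reported once more only as a limit.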

Compound 4, half-maximal inhibitory concentration: > 100000 nM
Compound 4: only a limit was reported; the forecaster's own chance of this, stated with the estimate: 85%; the middle value lies beyond the limit too.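

In this assay compound 4 gives > 100000 nM, a limit of the assay and not a number. No new step can be read from compound 1, compound 2 or compound 3 to compound 4, because all the values sit at one point: the limit of > 100000 nM in this assay, at which 4 of the 4 values shown sit. The compounds shown leave open whether any change on the shared core alters cytotoxicity in these cells.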